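A few compounds are considered here, and "the series" means these few. Any claim that something is new, unique, unknown or untested is made for them only; others in the source may bear on it.

Within the data shown here, compound 2 `Cc1ccc(S(=O)(=O)Nc2cccc(/C=C/C(=O)c3nc4ccccc4[nH]3)c2)cc1` gives 3220 nM in a functional assay on MCF7 cells (Homo sapiens) for antiproliferative activity, read by MTT assay, with a stated time of 48 h (a lower number here means a stronger inhibitor, a higher number a weaker inhibitor), the highest of the two numbers measured so far; its nearest neighbour is compound 1 `Cc1cccc(S(=O)(=O)Nc2cccc(/C=C/C(=O)c3nc4ccccc4[nH]3)c2)c1`, which gives 886 nM. Among the measured compounds shown here, the single measured step, a 3.6-fold higher number from compound 1 to compound 2 (0.56 log units; beyond the scatter), shows that the arrangement of substituents on the ring attached to the sulfonyl sulfur matters, with a change that moves the sulfonyl-bearing ring from 3-methylphenyl to 4-methylphenyl. Compound 3 `O=C(/C=C/c1cccc(NS(=O)(=O)c2cc(Cl)cc(Cl)c2)c1)c1nc2ccccc2[nH]1` differs from compound 2 by 3,5-dichlorophenyl in place of 4-methylphenyl on a sulfonyl sulfur. For the measured compounds named here, no measured step covers chlorine in place of methyl, so the direction is uncertain; the only guide is that the substituent pattern on this ring shifted the value beyond the scatter once. Compound 3 is therefore expected to land near compound 2 or somewhat below it, with a wide range, an estimated 1500 nM (between 350 nM and 6500 nM), corresponding to an expected step of a 2.1-fold lower number from compound 2 to compound 3 (0.33 log units; beyond the scatter).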

Compound 3, half-maximal inhibitory concentration: 20000 nM
Compound 3: middle estimate off by 13-fold (1.12 log units), on the low side, and the stated range ends below it.
By their numbers in this assay, from the lowest: compound 1; then compound 2; then compound 3.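

On the ring attached to the sulfonyl sulfur, 3,5-dichlorophenyl gives the weakest compound of the three in this assay, with a 6.2-fold higher number from compound 2 to compound 3 (0.79 log units; beyond the scatter) and a 23-fold higher number from compound 1 to compound 3 (1.35 log units; beyond the scatter). The earlier pair showed only what happens when a single methyl group changes place; this result shows that replacing the methyl-bearing ring with a dichlorinated one also raises the number, and the step from the 3-methylphenyl compound is large rather than modest. (Nothing measured here accounts for this rise).

On these data alone, whether the rise belongs to chlorine itself or to the presence of two substituents remains open. As far as these compounds go, it is also open how a ring carrying a single chlorine, a methoxy group or an amine would compare at this position.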